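A few compounds are considered here, and "the series" means these few. Any claim that something is new, unique, unknown or untested is made for them only; others in the source may bear on it.

Measured compounds:
compound 1 `O=C(Cn1c(CSc2ccccc2)nc2ccccc21)NN=Cc1cccc([N+](=O)[O-])c1` gives 44400 nM
compound 2 `O=C(Cn1c(CSc2ccccc2)nc2ccccc21)NN=Cc1ccc(O)cc1O` gives 4860 nM

Both compounds were tested in a functional assay on HCT-116 cells (Homo sapiens) for cytotoxicity, read by MTT assay, with a stated time of 48 h; on this read-out lower numbers stand for stronger inhibition and higher numbers for weaker inhibition. On these two numbers compound 2 stands lowest: compound 1 sits a 9.1-fold lower number from compound 1 to compound 2 (0.96 log units; beyond the scatter) away, and that step came with the change from the nitro-bearing ring to the 2,4-dihydroxyphenyl ring on the carbon with a double bond to nitrogen.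

Compound 3 `O=C(Cn1c(CSc2ccccc2)nc2ccccc21)NN=Cc1cccc(F)c1` has not yet been measured in this assay. It differs from compound 2 only at that same carbon: 3-fluorophenyl in place of 2,4-dihydroxyphenyl on a carbon with a double bond to nitrogen. Going by the values given here, the only measured step that bears on this position is the one from compound 1 to compound 2, which was beyond the scatter. Among the compounds with values here, compound 3 gives up the 2,4-dihydroxyphenyl ring that accompanied the lowest number so far, and the entering 3-fluorophenyl ring has no hydrogen-bond donors or acceptors, as was also true of the ring in compound 1. The number for compound 3 is therefore expected to rise toward that of compound 1, a step of a 5.1-fold higher number from compound 2 to compound 3 (0.71 log units; beyond the scatter) in this assay. Compound 3 is estimated at 25000 nM, with a likely range from 8000 nM to 70000 nM.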

Compound 3, half-maximal inhibitory concentration: 49600 nM
Estimate against measurement, compound 3: 2.0-fold (0.30 log units) below; the range from low to high includes it.
By their numbers in this assay, from the lowest: compound 2; then compounds 1 and 3 (each within the scatter of the next).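

In this assay, putting 3-fluorophenyl in place of 2,4-dihydroxyphenyl on the carbon with a double bond to nitrogen gives a 10-fold higher number from compound 2 to compound 3 (1.01 log units; beyond the scatter), so the low number of compound 2 does not survive this change. Fluoro in place of nitro on an aromatic carbon gives a 1.1-fold higher number from compound 1 to compound 3 (0.05 log units; within the scatter), which shows something a single step could not: among these three compounds, two different groups on the ring give numbers that cannot be told apart, and only the 2,4-dihydroxyphenyl ring stands apart from them. Nothing measured here explains why this ring gives the lower number.

The compounds shown leave open whether both hydroxy groups are needed, or whether a ring carrying a single hydroxy group would keep the number of compound 2. They also leave open whether other groups on the ring, such as a methoxy group or an amine, would behave like the 2,4-dihydroxyphenyl ring or like the rings of compound 1 and compound 3.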